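Small steps among phenyl amides in growth inhibition

The source may report more compounds than this note shows. Statements on the series, on what has been measured and on what is new or still open speak of the compounds shown alone.

- compound 1 `COc1ccc(NC(=O)C2(C(=O)Nc3ccc(Nc4ncc5cc(C(=O)N(C)C)n(C6CCCC6)c5n4)cc3)CC2)cc1` gives 96.1%
- compound 2 `CN(C)C(=O)c1cc2cnc(Nc3ccc(NC(=O)C4(C(=O)Nc5ccccc5F)CC4)cc3)nc2n1C1CCCC1` gives 97.8%
- compound 3 `CN(C)C(=O)c1cc2cnc(Nc3ccc(NC(=O)C4(C(=O)Nc5cccc(Cl)c5)CC4)cc3)nc2n1C1CCCC1` gives 92.6%

All three numbers come from a functional assay on T47D cells (Homo sapiens) for inhibition, read by CCK-8 assay, with a stated time of 72 h, tested at 10 uM (a lower number here means less inhibition of growth, a higher number more inhibition of growth at the concentration tested), and sit close together. Compound 3 stands level with the other two, as a number 3.5 percentage points lower from compound 1 to compound 3 (within the scatter) and a number 5.2 percentage points lower from compound 2 to compound 3 (within the scatter) show. Compound 4 `CN(C)C(=O)c1cc2cnc(Nc3ccc(NC(=O)C4(C(=O)Nc5ccc(Br)cc5)CC4)cc3)nc2n1C1CCCC1` carries 4-bromophenyl in place of 3-chlorophenyl on an amide-type nitrogen. Those two steps bear on this change, along with a number 1.7 percentage points higher from compound 1 to compound 2 (within the scatter) as a third swap on the same nitrogen. All three stayed small, so no step beyond the scatter is expected here. The expected step is a number 1.4 percentage points higher from compound 3 to compound 4 (within the scatter) and no more than that. In this assay compound 4 is expected at 94% (86% to 99%).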

Compound 4, percent growth inhibition at one concentration: 94.3%
Beside the measured number, compound 4's estimate is 0.3 percentage points below it; measured number inside the range.
By their numbers in this assay, from the lowest: compounds 3, 4, 1 and 2 (each within the scatter of the next).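

On this amide-type nitrogen, 4-bromophenyl in place of 3-chlorophenyl gives a number 1.7 percentage points higher from compound 3 to compound 4 (within the scatter) and in place of 2-fluorophenyl gives a number 3.5 percentage points lower from compound 2 to compound 4 (within the scatter). Bromo in place of methoxy on an aromatic carbon gives a number 1.8 percentage points lower from compound 1 to compound 4 (within the scatter), so a bromo-bearing phenyl now stands level with the chloro, fluoro and methoxy versions in this assay. Nothing available explains why these groups stand level.

On these data alone, whether these four compounds would separate at lower concentrations stays open. So does the outcome for a phenyl carrying an amine or a carboxylic acid, or for a plain alkyl chain replacing the phenyl.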